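The compounds below may be only part of what the source reports. "The series", "measured", "known", "first", "only" and "open" are said of these compounds alone.

Compound 1 `COc1cc(-c2nn(-c3cccc(NC(=O)Nc4cc(C(F)(F)F)cc(C(F)(F)F)c4)c3)cc2-c2ccncc2)ccc1Cl` and compound 2 `O=C(Nc1cccc(-n2cc(-c3ccncc3)c(-c3ccc(Cl)c(O)c3)n2)c1)Nc1cc(C(F)(F)F)cc(C(F)(F)F)c1` share a core and were both tested in a functional assay on ACHN cells (Homo sapiens) for inhibition, read by sulforhodamine B assay, with a stated time of 48 h; a higher number here means a weaker inhibitor of growth, a lower number a stronger inhibitor of growth. Compound 1 gives 5720 nM, and compound 2 gives 5270 nM. The change between them is hydrogen in place of methyl on an oxygen on an aromatic ring and the step it made was a 1.1-fold lower number from compound 1 to compound 2 (0.04 log units; within the scatter).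

Compound 3 `COc1cc(-c2nn(-c3cccc(NC(=O)Nc4ccc(Cl)c(C(F)(F)F)c4)c3)cc2-c2ccncc2)ccc1Cl` carries a different core; the difference between its core and that of compound 1 is not broken down here. In this assay compound 3 gives 15600 nM, the highest of the three numbers, a step beyond the scatter from compound 1 and from compound 2.

Compound 4 `O=C(Nc1cccc(-n2cc(-c3ccncc3)c(-c3ccc(Cl)c(O)c3)n2)c1)Nc1ccc(Cl)c(C(F)(F)F)c1` has not been measured. It differs from compound 3 by hydrogen in place of methyl on an oxygen on an aromatic ring, which is the same change as that from compound 1 to compound 2, made at a place described in the same words. Among the four compounds this change occurs twice. Because the earlier step was a 1.1-fold lower number from compound 1 to compound 2 (0.04 log units; within the scatter), the step from compound 3 to compound 4 is expected to be of similar size, about a 1.1-fold lower number from compound 3 to compound 4 (0.03 log units; within the scatter), and the expectation rests on that single earlier pair alone. On that basis compound 4 is expected to give about 14500 nM in this assay, estimated to lie between 6000 nM and 35000 nM.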

Compound 4, concentration for total growth inhibition: > 32500 nM
Compound 4: no number, only a limit; the forecaster's own chance of this, stated with the estimate: 10%; middle value at least 2.2-fold (0.35 log units) away from the limit.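

In this assay compound 4 gives > 32500 nM, which is a limit of the assay and not a number. Read with that limit in mind, the change from methoxy to hydroxy gave an at least 2.0-fold higher number from compound 3 to compound 4 (0.31 log units; beyond the scatter), whereas on the other core the same change gave a 1.1-fold lower number from compound 1 to compound 2 (0.04 log units; within the scatter). One step lies within the scatter and the other beyond it, yet this does not establish that the change behaves differently on the two cores, and it gives no exact size for the newer step: the same change on two cores in this assay, a 1.1-fold lower number (0.04 log units; within the scatter) from compound 1 to compound 2 and an at least 2.0-fold higher number (0.31 log units; beyond the scatter) from compound 3 to compound 4; the limit leaves it open whether they differ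

The compounds shown leave open how an amine, a carboxylic acid or a longer chain on that oxygen-bearing position of the 4-chloro-3-methoxyphenyl group would read in this assay, since only methoxy and hydroxy appear there, on just two cores. They also leave open the true value of compound 4, so that a firm comparison of the two steps remains out of reach, and only one compound in the set is affected in this way: the limit of > 32500 nM in this assay, at which 1 of the 4 values shown sits.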